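Methyl removal on the selenium aryl of compound 1

The source may hold more compounds than are shown below. What is called first, only, known or untested is meant among the compounds shown, and "the series" means these compounds.

Compound 1 `CCOC(=O)c1cc([Se]c2ccccc2C)c2cc(OC)ccc2n1` gives 38900 nM in a functional assay on SK-MEL-147 cells (Homo sapiens) for cytotoxicity, read by MTT assay, with a stated time of 24 h (a lower number here means that less compound is needed, a higher number that more compound is needed for the effect), and stands at the low end of the three numbers in hand, with compound 2 close to it and compound 3 further off. Compound 2 `CCOC(=O)c1cc([Se]Cc2ccccc2)c2cc(OC)ccc2n1` gives 40700 nM, and compound 3 `CCOC(=O)c1cc([Se]c2ccccc2)c2ccccc2n1` gives 86300 nM. The step of a 1.0-fold higher number from compound 1 to compound 2 (0.02 log units; within the scatter) shows that swapping the group on selenium for a different one leaves the number where it was. Compound 3 differs from compound 1 in two places at once, the methoxy on the shared core and the methyl on the selenium aryl, so its higher number cannot be split between the two.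

Compound 4 `CCOC(=O)c1cc([Se]c2ccccc2)c2cc(OC)ccc2n1` arises from compound 1 by hydrogen in place of methyl on an aromatic carbon. Among the measured compounds shown here, the only single step that bears on it, a 1.0-fold higher number from compound 1 to compound 2 (0.02 log units; within the scatter), replaced the whole group on selenium without moving the number, which suggests that trimming one methyl from it should not move it either. Compound 3 carries the same phenyl on selenium and sits higher than compound 1, but lacks the methoxy, so it offers no more than a hint that a somewhat higher number is possible. The expected step is therefore a 1.2-fold higher number from compound 1 to compound 4 (0.09 log units; within the scatter), nothing beyond the scatter. Compound 4 is estimated at 48000 nM, within a range of 24000 nM to 96000 nM.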

Compound 4, half-maximal effective concentration: 33000 nM
Compound 4: the middle estimate sits 1.5-fold (0.16 log units) above what was measured; the range from low to high includes it.
By their numbers in this assay, from the lowest: compounds 4, 1 and 2 (each within the scatter of the next); then compound 3.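

Taken alone, the methyl on the aromatic carbon ortho to a large group makes no readable difference in this assay: a 1.2-fold lower number from compound 1 to compound 4 (0.07 log units; within the scatter), so going from 2-methylphenyl to phenyl leaves the number in place. Among the compounds shown here, with phenyl on selenium in both compounds, the methoxy on the shared core can now be read by itself, and a 2.6-fold lower number from compound 3 to compound 4 (0.42 log units; beyond the scatter) is the only step so far that lies beyond the scatter, a modest one that goes with methoxy in place of hydrogen rather than with any change on selenium. The third step, a 1.2-fold lower number from compound 2 to compound 4 (0.09 log units; within the scatter), joins the earlier step between 2-methylphenyl and benzyl, so among compounds 1, 2 and 4, which all carry the methoxy, these three groups on selenium cannot be told apart by this read-out.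

Open, from the compounds shown here alone, is whether this flat response extends to a group of another kind on the same aromatic ring, such as an amine or a carboxylic acid, or to a longer chain on selenium, and whether a larger step can be found at either place. Nothing at hand gives a measured reason for the methoxy step or for the flat response on selenium.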